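The source may hold more compounds than are shown below. What is called first, only, known or untested is meant among the compounds shown, and "the series" means these compounds.

Measured so far:
compound 1 `CC(C)C[C@H](NC(=O)[C@H](NC(=O)c1cnccn1)C(C)C)B(O)O` — in an assay on isolated protein for inhibition of Lon protease homolog, mitochondrial (Homo sapiens), read by HTRF, with a stated time of 50 min, in the presence of a further agent that is not named here (on this read-out higher numbers stand for weaker inhibition and lower numbers for stronger inhibition), compound 1 gives 546 nM
compound 2 `CC(C)C[C@H](NC(=O)[C@H](NC(=O)c1cnccn1)C(C)(C)C)B(O)O` — compound 2 gives 2850 nM

For the measured compounds named here, compound 2 stands at the higher of the two numbers; its only comparator is compound 1, and the step of a 5.2-fold higher number from compound 1 to compound 2 (0.72 log units; beyond the scatter) lies beyond the scatter. Compound 3 `CC(C)C[C@H](NC(=O)[C@@H](CC1CCCCC1)NC(=O)c1cnccn1)B(O)O` differs from compound 2 in one place: cyclohexylmethyl in place of tert-butyl on a saturated chain carbon bound to an amide-type nitrogen and a carbonyl carbon. Going by the values given here, the single measured step that bears on this position is a 5.2-fold higher number from compound 1 to compound 2 (0.72 log units; beyond the scatter), a modest rise. Among the compounds with values here, no measured step covers a cyclohexylmethyl at this carbon. Compound 3 is therefore expected to shift by a 3.2-fold lower number from compound 2 to compound 3 (0.50 log units; beyond the scatter), with an estimated 900 nM and a range from 250 nM to 3200 nM.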

Compound 3, half-maximal inhibitory concentration: 137 nM
For compound 3 the middle estimate is 6.6-fold (0.82 log units) above the measured one; the measured number lies below the stated range.
By their numbers in this assay, from the lowest: compound 3; then compound 1; then compound 2.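

At this position, on a saturated chain carbon bound to an amide-type nitrogen and a carbonyl carbon, cyclohexylmethyl more than recovers what tert-butyl lost (a 21-fold lower number from compound 2 to compound 3 (1.32 log units; beyond the scatter)) and also improves on isopropyl (a 4.0-fold lower number from compound 1 to compound 3 (0.60 log units; beyond the scatter)). A larger group here therefore does not always mean weaker inhibition, and compound 3 goes against any such reading of the earlier step. Nothing at hand explains the difference between these groups.

Going by these compounds, what a cyclohexyl group placed directly on this carbon would give stays open, and the same holds for a benzyl group or a longer chain.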